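Shortening the amine chain on a shared core

The compounds below may be only part of what the source reports. "The series", "measured", "known", "first", "only" and "open" are said of these compounds alone.

Two compounds share one core and differ only in the amine attached to it. Compound 1 `CCCCC(CC)Nc1nc(C)nc2c(-c3ccc(Cl)cc3Cl)c(C)nn12` carries a branched (1-ethylpentyl)amino group, and in an assay on isolated protein for displacement of a labelled ligand from corticotropin-releasing factor receptor 1 (Homo sapiens) (a lower number here means a stronger inhibitor, a higher number a weaker inhibitor), compound 1 gives 1.6 nM. Compound 2 `CCCCN(CC)c1nc(C)nc2c(-c3ccc(Cl)cc3Cl)c(C)nn12` carries a butyl(ethyl)amino group instead, and in this assay compound 2 gives 0.4 nM. That single swap brought a 4.0-fold lower number from compound 1 to compound 2 (0.60 log units; beyond the scatter), so compound 2 holds the lower of the two numbers, its nearest neighbour being compound 1.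

Compound 3 `CCN(CC)c1nc(C)nc2c(-c3ccc(Cl)cc3Cl)c(C)nn12` takes the step further: hydrogen in place of ethyl on a saturated chain carbon, two bonds along the chain from a nitrogen on an aromatic ring, so the butyl(ethyl)amino group becomes diethylamino. For the measured compounds named here, no measured step shows this kind of shortening; the only step in hand, from compound 1 to compound 2, changed the branching and the nitrogen substitution at once, and is therefore only a loose guide. Given that the one measured change at this amine moved the number modestly, compound 3 is expected to stay close to compound 2, with a 2.5-fold higher number from compound 2 to compound 3 (0.40 log units; beyond the scatter) as the estimated step. Compound 3 is thus estimated at 1 nM, likely between 0.3 nM and 3.5 nM.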

Compound 3, inhibition constant: 1.2 nM
The estimate for compound 3 lay 1.2-fold (0.08 log units) below the measured number; the range from low to high includes it.
By their numbers in this assay, from the lowest: compound 2; then compounds 3 and 1 (each within the scatter of the next).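

Taking the chain on the nitrogen from butyl to ethyl gives, in this assay, a 3.0-fold higher number from compound 2 to compound 3 (0.48 log units; beyond the scatter) and so separates chain length from the branching and nitrogen substitution that changed together in the earlier step. Chain length alone therefore registers at this position, and the diethylamino group of compound 3 does not keep the number of compound 2. The step of a 1.3-fold lower number from compound 1 to compound 3 (0.12 log units; within the scatter) leaves the diethylamino and (1-ethylpentyl)amino groups indistinguishable here, so having two chains on the nitrogen does not by itself give a number like that of compound 2, and the difference rests with the butyl(ethyl)amino group among these three compounds. Nothing available explains why the shorter chain gives the higher number.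

The compounds shown leave open how a propyl chain, which would sit in length between the ethyl and butyl chains, or a longer pentyl chain would read in this position. They also leave open whether a ring amine such as pyrrolidine, or a chain carrying an ether oxygen such as methoxyethyl, could match butyl(ethyl)amino.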